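Trading a Pyridine for a Small Sulfur-Nitrogen Ring

The source may report more compounds than this note shows. Statements on the series, on what has been measured and on what is new or still open speak of the compounds shown alone.

Compound 1 `CCC(C)(C)Cc1c[nH]c(CCc2ccc(-c3ccncc3)cc2)n1` pairs a long branched alkyl chain on the shared core with a pyridin-4-yl group at the far end. In a functional assay on HEK293 cells for agonist activity at Bombesin receptor subtype-3 (Mus musculus), read by luminescence and calcium flux, with a stated time of 10 min (on this read-out lower numbers stand for an effect already at smaller amounts and higher numbers for an effect only at larger amounts of compound), compound 1 gives 15 nM. Its two measured neighbours are compound 2 `CCC(C)(C)Cc1c[nH]c(CCc2ccc(-c3cccc(C#N)n3)cc2)n1`, which gives 26 nM, and compound 3 `CCC(C)(C)Cc1c[nH]c(CCc2ccc(-c3csnn3)cc2)n1`, which gives 11 nM. Compound 1 thus holds the second highest of the three numbers, but both of its steps, a 1.7-fold higher number from compound 1 to compound 2 (0.24 log units; within the scatter) and a 1.4-fold lower number from compound 1 to compound 3 (0.13 log units; within the scatter), stay within the scatter. Among the measured compounds shown here, only the step of a 2.4-fold lower number from compound 2 to compound 3 (0.37 log units; beyond the scatter) reaches beyond it, and only modestly.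

Compound 4 `CCC(C)(C)Cc1c[nH]c(CCc2ccc(-c3ccns3)cc2)n1` differs from compound 1 in one place: 1,2-thiazol-5-yl in place of pyridin-4-yl on an aromatic carbon. For the measured compounds named here, the closest precedent is the step from compound 1 to compound 3, where another small five-membered ring with two hetero atoms replaced the same pyridine without moving the number beyond the scatter. A similar outcome is expected here: no step beyond the scatter in either direction. Compound 4 is therefore estimated at 12 nM, with a range from 5 nM to 30 nM. That estimate corresponds to an expected step of a 1.3-fold lower number from compound 1 to compound 4 (0.10 log units; within the scatter).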

Compound 4, half-maximal effective concentration: 3.1 nM
Beside the measured number, compound 4's estimate is 3.9-fold (0.59 log units) above it; measured number outside the range, below it.
By their numbers in this assay, from the lowest: compound 4; then compounds 3, 1 and 2 (each within the scatter of the next, the first and the last beyond it).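

Among the compounds shown here, compound 1 had so far looked insensitive to changes at this position. Neither earlier replacement of its pyridin-4-yl group moved the number beyond the scatter. The 1,2-thiazol-5-yl group is the only replacement shown that does (the change gives a 4.8-fold lower number from compound 1 to compound 4 (0.68 log units; beyond the scatter)). Having a five-membered aromatic ring there does not settle the outcome, as two such rings still differ measurably (a 3.5-fold lower number from compound 3 to compound 4 (0.55 log units; beyond the scatter)), and the largest gap in the set is the one against the 6-cyanopyridin-2-yl group (an 8.4-fold lower number from compound 2 to compound 4 (0.92 log units; beyond the scatter)).

Nothing available here accounts for these differences. Also open, going by these compounds, is how a methyl group or an amine on the 1,2-thiazol-5-yl ring, or a shorter chain on the shared core, would behave in this assay.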